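Compound 2 and its (carboxymethyl)sulfanyl counterpart, compound 4

The compounds below may be only part of what the source reports. "The series", "measured", "known", "first", "only" and "open" are said of these compounds alone.

Measured in a functional assay on the whole organism (strain Hartley) for inhibition, with Cavia porcellus as the target, with stated times of 15 min and 2 min; a lower number here means that less compound is needed, a higher number that more compound is needed for the effect:
Compound 1 `CCCCC1([C@@H](O)/C=C/C2[C@H](O)CC(=O)[C@@H]2CCCCCCC(=O)O)CCC1`: 0.017 mg/kg
Compound 2 `CCCCC1([C@@H](O)/C=C/C2CCC(=O)[C@@H]2CCCCCCC(=O)O)CCC1`: 0.0139 mg/kg
Compound 3 `CCCCC1([C@H](O)/C=C/C2CCC(=O)[C@@H]2CCCCCCC(=O)O)CCC1`: 0.0024 mg/kg

The value of compound 2 is 0.0139 mg/kg, the second highest of the three numbers. Its nearest neighbour gives a 1.2-fold lower number from compound 1 to compound 2 (0.09 log units; within the scatter), while its furthest gives a 5.8-fold lower number from compound 2 to compound 3 (0.76 log units; beyond the scatter).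

The next compound is compound 4 `CCCCC1([C@@H](O)/C=C/C2CCC(=O)[C@@H]2CCCCSCC(=O)O)CCC1`. The change is (carboxymethyl)sulfanyl in place of 2-carboxyethyl on a saturated chain carbon, four bonds along the chain from a saturated ring carbon: (carboxymethyl)sulfanyl stands in place of 2-carboxyethyl on a saturated chain carbon, four bonds along the chain from a saturated ring carbon.

Neither measured step touches this part of the chain, so both bear on it only indirectly. Hydrogen in place of hydroxy on a saturated ring carbon gave a 1.2-fold lower number from compound 1 to compound 2 (0.09 log units; within the scatter). A stereocentre at a saturated chain carbon gave a 5.8-fold lower number from compound 2 to compound 3 (0.76 log units; beyond the scatter), and that step comes with the fact that one of compounds 2 and 3 is drawn with a defined configuration and the other without, at the place where they differ. Going by the values given here, the second step shows that one change can move the number beyond the scatter, but there is no measured precedent for the sulfanyl exchange, so no direction can be argued. The expected outcome in this assay is therefore no step beyond the scatter, and the estimate is a 1.0-fold higher number from compound 2 to compound 4 (0.00 log units; within the scatter), with a wide margin on either side. For compound 4 the estimated value is 0.014 mg/kg, with an expected range from 0.004 mg/kg to 0.05 mg/kg.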

Compound 4, dose for half-maximal effect: 0.606 mg/kg
Compound 4: the middle estimate sits 43-fold (1.64 log units) below what was measured; measured number outside the range, above it.
By their numbers in this assay, from the lowest: compound 3; then compounds 2 and 1 (each within the scatter of the next); then compound 4.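

In this assay, (carboxymethyl)sulfanyl in place of 2-carboxyethyl on a saturated chain carbon, four bonds along the chain from a saturated ring carbon, gives a 44-fold higher number from compound 2 to compound 4 (1.64 log units; beyond the scatter). Going by these compounds alone, this is the first measured change at this part of the chain, and it shows that the number is highly sensitive here, even though the two groups hold the same count of heavy atoms, neither has a ring, and both end in the same acid; the earlier steps, a 1.2-fold lower number from compound 1 to compound 2 (0.09 log units; within the scatter) and a 5.8-fold lower number from compound 2 to compound 3 (0.76 log units; beyond the scatter), concerned a ring hydroxy and a stereocentre and could not show this. What the exchange does to produce this step remains unexplained, since nothing at hand bears on its cause.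

The compounds shown cannot separate the effect of the sulfur itself from that of its place in the chain, which an ether oxygen at the same spot, or a longer chain between the sulfur and the carboxylic acid, would speak to. They also leave open whether the sulfanyl exchange costs as much with the chain stereocentre drawn as in compound 3, or with the ring hydroxy of compound 1 present.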